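Moving the pyridine out on a methyl link

This account rests on a few compounds, and the source may have more. Where it says the series, first, only, none or still open, it means among the compounds named here.

Measured compounds:
compound 1 `O=C(NO)c1ccc(Cn2nnc(-c3cccc(S(F)(F)(F)(F)F)c3)n2)cc1` gives 26 nM
compound 2 `O=C(O)c1cccc(-c2nnn(Cc3ccc(C(=O)NO)cc3)n2)c1` gives 12 nM
compound 3 `O=C(NO)c1ccc(Cn2nnc(-c3ccccn3)n2)cc1` gives 9 nM

All three share one core and differ only in the group on the five-membered aromatic ring. In an assay on Sf9 cells for inhibition of protein deacetylase HDAC6 (Homo sapiens), read by fluorescence (on this read-out higher numbers stand for weaker inhibition and lower numbers for stronger inhibition), compound 3 gives the lowest of the three numbers; compound 2 is nearest and within the usual scatter of it, while compound 1 is furthest and beyond it. Compound 4 `O=C(NO)c1ccc(Cn2nnc(Cc3ccccn3)n2)cc1` is the one not yet measured. It differs from compound 3 in one place: (pyridin-2-yl)methyl in place of pyridin-2-yl on an aromatic carbon. For the measured compounds named here, no measured step touches this kind of change. Going by the values given here, the single step on record, a 2.2-fold lower number from compound 1 to compound 2 (0.34 log units; beyond the scatter), swaps one group for another on the aromatic carbon of the outer ring and is modest; it shows that this part of the molecule can be altered without large swings, but it says nothing about a methyl link. Compound 4 is therefore expected to land close to compound 3, with the step of a 2.0-fold higher number from compound 3 to compound 4 (0.30 log units; within the scatter) probably not clearly beyond the scatter. The estimate for compound 4 is 18 nM, within 6 nM to 60 nM.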

Compound 4, half-maximal inhibitory concentration: 25 nM
Compound 4: middle estimate off by 1.4-fold (0.14 log units), on the low side, and the stated range covers the measured number.
By their numbers in this assay, from the lowest: compounds 3 and 2 (each within the scatter of the next); then compounds 4 and 1 (each within the scatter of the next).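

Replacing pyridin-2-yl with (pyridin-2-yl)methyl on the aromatic carbon of the five-membered ring raises the number in this assay (a 2.8-fold higher number from compound 3 to compound 4 (0.44 log units; beyond the scatter)), so inhibition becomes weaker. The earlier step changed only a group carried on the outer ring, whereas this one changes how that ring is joined to the shared core. Even a methyl link moves the number beyond the usual scatter, although the step remains modest, so the direct attachment of the pyridine matters at this position. Nothing measured here explains this shift. The compounds shown leave open whether a longer chain, such as an ethyl link, would raise the number further, and whether an amine link would behave like the methyl link. They also leave open whether a methyl link would have the same effect with a plain phenyl ring in place of the pyridine.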